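The source may hold more compounds than are shown below. What is called first, only, known or untested is meant among the compounds shown, and "the series" means these compounds.

Compound 2 `Nc1cc(N)c2nc(-c3ccccc3)c(Sc3ccc(Cl)c(Cl)c3)nc2c1` carries a (3,4-dichlorophenyl)sulfanyl group on the shared core; in a functional assay on SF-539 cells (Homo sapiens) for inhibition, read by sulforhodamine B assay, with a stated time of 48 h (on this read-out higher numbers stand for lower toxicity in this test and lower numbers for higher toxicity in this test), compound 2 is recorded only as a limit, < 100000 nM. Compound 1 `Nc1cc(N)c2nc(-c3ccccc3)c(NCc3ccc(F)cc3)nc2c1` bears a (4-fluorobenzyl)amino group at that carbon, and in this assay compound 1 gives 6920 nM. The step that the limit leaves unreadable from compound 1 to compound 2 cannot be sized because one of its two ends sits at the limit (the limit of < 100000 nM in this assay, at which 1 of the 2 values shown sits). Compound 3 `Nc1cc(N)c2nc(-c3ccccc3)c(Oc3ccc(F)cc3)nc2c1` is still unmeasured: 4-fluorophenoxy in place of (3,4-dichlorophenyl)sulfanyl on an aromatic carbon. Among the measured compounds shown here, no measured step bears on this exchange with a readable size; the step that the limit leaves unreadable from compound 1 to compound 2 is the only one that touches compound 2, and the limit leaves it unread. The direction and size of the move from compound 2 to compound 3 in this assay therefore cannot be drawn from the numbers shown, and the expectation rests on compound 1 with 6920 nM, whose 4-fluorobenzyl group is the closest structural relative of the entering 4-fluorophenoxy. Compound 3 is expected near 12000 nM, between 2500 nM and 60000 nM, which is estimated to mean a step that the limit leaves unreadable from compound 2 to compound 3.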

Compound 3, concentration lethal to 50% of the cells: 70800 nM
Estimate against measurement, compound 3: 5.9-fold (0.77 log units) below; the measured number lies above the stated range.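

At the aromatic carbon next to the ring nitrogen, 4-fluorophenoxy in place of (4-fluorobenzyl)amino gives, in this assay, a 10-fold higher number from compound 1 to compound 3 (1.01 log units; beyond the scatter). Among the compounds shown here, this is the first readable step at this carbon: it shows that the read-out depends on the group held there, with the number moving towards lower toxicity in this test. Compound 2 is recorded only as a limit, and the steps that touch it cannot be read: the limit of < 100000 nM in this assay, at which 1 of the 3 values shown sits.

Compound 1 and compound 3 differ in both the atom attached to the ring carbon and the length of the link to the fluorophenyl ring, so the step cannot yet be assigned to either change. A (4-fluorophenyl)amino or a 4-fluorobenzyloxy group at this carbon would separate the two, and a (4-fluorophenyl)sulfanyl group would connect the series to the sulfur link of compound 2.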